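The source may report more compounds than this note shows. Statements on the series, on what has been measured and on what is new or still open speak of the compounds shown alone.

Three compounds in this set have entries, and a fourth awaits measurement. Compound 1 `Cc1noc(C)c1-c1cccc(Oc2ccc(C#N)c(C(F)(F)F)c2)c1` carries in a functional assay on PC-3 cells (Homo sapiens) for antiproliferative activity, read by CCK-8 assay, with a stated time of 6 days (a higher number here means a weaker inhibitor, a lower number a stronger inhibitor), the entry "not determined" (no result reported), meaning no result was reported. Compound 2 `N#Cc1ccc(N2CCCc3c(-c4ccncc4)cccc32)cc1C(F)(F)F` gives 28700 nM in this assay, a weak inhibition. Compound 3 `CCN(c1ccc(C#N)c(Cl)c1)c1cc(-c2ccccc2)ccc1C` likewise shows "not determined" (no result reported) in this assay, so no number places it among these compounds; it is one of two entries without a single value. Compound 4 `CCN(c1ccc(C#N)c(Cl)c1)c1cc(-c2ccoc2)ccc1C` differs from compound 3 in one place: furan-3-yl in place of phenyl on an aromatic carbon. For the measured compounds named here, no measured pair shows the effect of this change, so its size and direction in this assay cannot be read from the data; a shift within the scatter seems most likely. With compound 2 at 28700 nM as the only reference, weak activity is anticipated. Compound 4 is expected to give about 20000 nM in this assay, within an estimated range of 5000 nM to 60000 nM.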

Compound 4, half-maximal inhibitory concentration: > 30000 nM
Compound 4: no number, only a limit; the forecaster's own chance of this, stated with the estimate: 30%; middle value at least 1.5-fold (0.17 log units) from the limit.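

Compound 4 gives > 30000 nM, which is a limit and not a number. For the compounds shown here, compound 3 has no single value, so no step between compound 3 and compound 4 can be read. Going by these compounds, how furan-3-yl in place of phenyl affects this assay stays open.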